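Swapping a Hydroxymethyl for a Propynyl on a Nucleoside

This account rests on a few compounds, and the source may have more. Where it says the series, first, only, none or still open, it means among the compounds named here.

Of the compounds shown here, three have been tested in an ADME assay on L1210/0 cells (Mus musculus) for cytotoxicity, with a stated time of 48 h; a higher number here means a weaker inhibitor, a lower number a stronger inhibitor. Compound 1 `O=C1O/C(=C/Cn2cnc3c(-n4cccc4)ncnc32)C(OCc2ccccc2)=C1OCc1ccccc1` gives 110000 nM. Compound 2 `O=c1[nH]c(=O)n([C@H]2C[C@H](O)[C@@H](CO)O2)cc1CO` gives 9180 nM. Compound 3 `O=c1ccn(C[C@@H]2CCC[C@H]2CO)c(=O)[nH]1` is recorded only as a limit of the assay, > 200000 nM, and so gives no number. Of the two numbers that exist, compound 2 has the lowest, and the number of compound 1 stands well above it, a gap that is beyond the usual scatter of repeated measurements. One of the three results sits at the limit (the limit of > 200000 nM in this assay, at which 1 of the 3 values shown sits).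

Compound 4 `CC#Cc1cn([C@H]2C[C@H](O)[C@@H](CO)O2)c(=O)[nH]c1=O` has not yet been measured in this assay. It differs from compound 2 in a single place (prop-1-yn-1-yl in place of hydroxymethyl on an aromatic carbon). Among the measured compounds shown here, no pair of measured compounds shows what this kind of swap does, so the step has to be judged from the structures alone. A change of roughly this size, where a hydroxymethyl leaves and a prop-1-yn-1-yl enters on the same aromatic carbon, is expected to move the number somewhat downward rather than leave it unchanged, though a step within the scatter cannot be ruled out. On that basis compound 4 is estimated at 4000 nM, within a range from 600 nM to 40000 nM, which would make the expected step of a 2.3-fold lower number from compound 2 to compound 4 (0.36 log units; beyond the scatter).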

Compound 4, half-maximal inhibitory concentration: > 200000 nM
Compound 4: only a limit was reported; the forecaster's own chance of this, stated with the estimate: 10%; middle value at least 50-fold (1.69 log units) away from the limit.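

In this assay compound 4 gives > 200000 nM, which is a limit of the assay and not a number. Placing prop-1-yn-1-yl instead of hydroxymethyl on this aromatic carbon of the six-membered aromatic ring with 2 nitrogen gives an at least 21-fold higher number from compound 2 to compound 4 (1.33 log units; beyond the scatter), so this one position can separate a compound with a measurable number from a compound with none, and the swap is far from neutral here. The true size of the step cannot be read, and the printed figure is only its lower bound, because compound 4 sits at a limit: the limit of > 200000 nM in this assay, at which 2 of the 4 values shown sit.

The compounds shown leave open whether the number rises with the loss of the hydroxymethyl, with the arrival of the prop-1-yn-1-yl, or with both, as this pair makes the two changes together. A methyl or an aminomethyl on the same carbon, with the rest of compound 2 unchanged, would begin to separate these possibilities and show how much change this position tolerates before the number reaches the limit.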